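Isoxazolyl deoxyuridine series: cytotoxicity notes, step to compound 4

This account rests on a few compounds, and the source may have more. Where it says the series, first, only, none or still open, it means among the compounds named here.

Measured so far:
compound 1 `CCCCc1ccc(-c2cc(-c3cn([C@H]4C[C@H](OC(C)=O)[C@@H](COC(C)=O)O4)c(=O)[nH]c3=O)on2)cc1`, 3000 nM
compound 2 `CCCCCCCCc1cc(-c2cn([C@H]3C[C@H](O)[C@@H](CO)O3)c(=O)[nH]c2=O)on1`, 3000 nM
compound 3 `CC(=O)OC[C@H]1O[C@@H](n2cc(-c3cc(C)no3)c(=O)[nH]c2=O)C[C@@H]1OC(C)=O`, 3000 nM

In an ADME assay on HeLa cells (Homo sapiens) for cytotoxicity (on this read-out higher numbers stand for lower toxicity in this test and lower numbers for higher toxicity in this test), compound 3 stands level with compounds 1 and 2; the three values are all within the scatter of one another, and compound 2, with its longer chain and free hydroxyls, shows the same reading as compound 3. Among the compounds with values here, the one single-place step known, no change at the digits printed from compound 1 to compound 3 (within the scatter), is flat.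

Compound 4 `CCCc1cc(-c2cn([C@H]3C[C@H](OC(C)=O)[C@@H](COC(C)=O)O3)c(=O)[nH]c2=O)on1` is the next member. Its difference from compound 3 is ethyl in place of hydrogen on a saturated chain carbon bound to an aromatic carbon. Within the data shown here, the only step that bears on it, no change at the digits printed from compound 1 to compound 3 (within the scatter), was a far larger exchange on the same aromatic carbon and moved nothing, so no step beyond the scatter is expected here: the expected change is no change at the digits printed from compound 3 to compound 4 (within the scatter). Compound 4 is therefore estimated at 3000 nM, within 1500 nM to 6000 nM.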

Compound 4, half-maximal cytotoxic concentration: 3000 nM
Compound 4: middle estimate and measured number agree at the digits printed; the measured number falls inside the stated range.
By their numbers in this assay, from the lowest: compounds 1, 2, 3 and 4 (each within the scatter of the next).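

Ethyl in place of hydrogen on a saturated chain carbon bound to an aromatic carbon gives no change at the digits printed from compound 3 to compound 4 (within the scatter) in this assay, so a first extension of this chain, methyl to propyl, reads flat. Propyl in place of 4-butylphenyl on the aromatic carbon gives no change at the digits printed from compound 1 to compound 4 (within the scatter) and so matches the earlier exchange to methyl. No measured evidence bears on why these readings coincide.

Open, from the compounds shown here alone, is whether a longer chain at this place, with both acetyl esters kept, stays level in this assay. Going by these compounds, an amine or a carboxylic acid at the end of the propyl chain is equally open.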